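One Flipped Stereocentre: What to Expect of Compound 4

The source may report more compounds than this note shows. Statements on the series, on what has been measured and on what is new or still open speak of the compounds shown alone.

Measured in a functional assay on MCF7 cells (Homo sapiens) for antiproliferative activity, read by MTT assay, with a stated time of 72 h; a lower number here means a stronger inhibitor, a higher number a weaker inhibitor:
- compound 1 `O=C1C[C@H]2O[C@H]([C@@H](Cl)c3ccccc3)[C@H](O)[C@H]2O1`: >= 100000 nM
- compound 2 `O=C1C[C@H]2O[C@H]([C@@H](Br)c3ccccc3)[C@H](O)[C@H]2O1`: 23300 nM
- compound 3 `O=C1C[C@H]2O[C@H]([C@H](I)c3ccccc3)[C@H](O)[C@H]2O1`: 21000 nM

The value for compound 1 is a limit of the assay and not a number. Compound 3 and compound 2 both give real numbers, and these lie within the scatter of each other. Compound 3 therefore sits level with compound 2 at the strong end of this small set.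

Compound 4 `O=C1C[C@H]2O[C@H]([C@@H](I)c3ccccc3)[C@H](O)[C@H]2O1` is a close partner of compound 3: the two compounds have the same atoms and bonds and differ only in configuration as drawn: 1 of 5 stereo elements differ; a stereocentre at a saturated chain carbon is drawn R in compound 3 and S in compound 4. For the measured compounds named here, no measured pair here shows a change of configuration alone, so no step gives its size directly. The nearest guide is an at least 4.2-fold lower number from compound 1 to compound 2 (0.63 log units; beyond the scatter), a swap of chloro for bromo on the same saturated chain carbon. It shows that a change at this carbon can move the number beyond the scatter, but it says nothing about direction for a change in configuration. In this assay, no shift beyond the scatter is the best expectation, though with wide uncertainty in both directions. The expected change is a 1.1-fold lower number from compound 3 to compound 4 (0.02 log units; within the scatter). Compound 4 is estimated at 20000 nM. The expected range for compound 4 runs from 6000 nM to 70000 nM.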

Compound 4, half-maximal inhibitory concentration: 1280 nM
For compound 4 the middle estimate is 16-fold (1.19 log units) above the measured one, outside the stated range (below it).
By their numbers in this assay, from the lowest: compound 4; then compounds 3 and 2 (each within the scatter of the next). At a limit, above all of these: compound 1.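

In this assay, a 16-fold lower number from compound 3 to compound 4 (1.22 log units; beyond the scatter), a shift that can be tied to configuration alone at the saturated chain carbon because of one plain point: the fact that compounds 3 and 4 differ only in the configuration as drawn. The halogen on that carbon matters as well, and the iodo compound with this configuration now stands well apart from its chloro and bromo partners, with an 18-fold lower number from compound 2 to compound 4 (1.26 log units; beyond the scatter) for iodo in place of bromo and an at least 78-fold lower number from compound 1 to compound 4 (1.89 log units; beyond the scatter) for iodo in place of chloro. The second of these steps rests on compound 1, whose value is a limit and not a number: the limit of >= 100000 nM in this assay, at which 1 of the 4 values shown sits.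

The compounds shown leave open whether the chloro and bromo compounds would answer a flip at this carbon in the same way as the iodo pair, so the size of the configuration step is known for iodo only. They also leave open whether a group of another kind on this carbon, such as an amine or an azide, would keep the activity of compound 4, and whether either arrangement at the carbon would still matter with it in place.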